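Furan-2-yl to furan-3-yl on the shared core

This account rests on a few compounds, and the source may have more. Where it says the series, first, only, none or still open, it means among the compounds named here.

Compound 1 `O=C(NCc1ccc(Cl)cc1Cl)[C@@H]1CCC(=O)N1c1cccs1` at 0.025 h
Compound 2 `O=C(NCc1ccc(Cl)cc1Cl)[C@@H]1CCC(=O)N1c1ccsc1` at 0.0417 h
Compound 3 `O=C(NCc1ccc(Cl)cc1Cl)[C@@H]1CCC(=O)N1c1ccco1` at 0.0867 h

These three half-lives all come from an ADME assay on microsomes from liver (Homo sapiens) for metabolic stability, read by HPLC, with a stated time of 60 min, tested at 0.2 mg/mL (on this read-out lower numbers stand for a shorter-lived compound and higher numbers for a longer-lived compound), and share one core, differing only in the five-membered aromatic ring on the nitrogen. Compound 3 has the highest of the three numbers (0.0867 h). The measured gaps are a 2.1-fold higher number from compound 2 to compound 3 (0.32 log units; beyond the scatter) and a 3.5-fold higher number from compound 1 to compound 3 (0.54 log units; beyond the scatter) and both are modest, though beyond the scatter.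

The next compound is compound 4 `O=C(NCc1ccc(Cl)cc1Cl)[C@@H]1CCC(=O)N1c1ccoc1`, which has furan-3-yl in place of furan-2-yl on an amide-type nitrogen in a ring. The two have the same atoms, joined differently.

The closest parallel is the matching swap among the thiophenes, thiophen-3-yl in place of thiophen-2-yl, where a 1.7-fold higher number from compound 1 to compound 2 (0.22 log units; within the scatter) stayed within the scatter. Among the compounds with values here, that is a single pair, and no measured pair of furans exists to test it. In this assay the expectation is therefore no step beyond the scatter, with a slight lean upward as in that parallel. The estimated step is small (a 1.3-fold higher number from compound 3 to compound 4 (0.10 log units; within the scatter)). For compound 4 the estimated half-life is 0.11 h (expected range 0.05 h to 0.24 h).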

Compound 4, half-life: 0.0483 h
Compound 4: the middle estimate sits 2.3-fold (0.36 log units) above what was measured; the measured number lies below the stated range.
By their numbers in this assay, from the lowest: compounds 1, 2, 4 and 3 (each within the scatter of the next, the first and the last beyond it).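

In this assay, moving the attachment point on the furan gives a 1.8-fold lower number from compound 3 to compound 4 (0.25 log units; within the scatter), so furan-3-yl and furan-2-yl on this amide-type nitrogen cannot be told apart, and the same holds for the thiophene pair at a 1.7-fold higher number from compound 1 to compound 2 (0.22 log units; within the scatter). Compound 4 also cannot be separated from either thiophene, with a 1.2-fold higher number from compound 2 to compound 4 (0.06 log units; within the scatter) and a 1.9-fold higher number from compound 1 to compound 4 (0.29 log units; within the scatter). Furan in itself therefore does not bring a step beyond the scatter: among these four compounds, only compound 3 has such steps, and only to compounds 1 and 2, so its modest separation from the thiophenes is not shared by compound 4.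

No measurement here offers a cause for any of these small steps. As far as these compounds go, it remains open whether a phenyl or a pyridin-3-yl ring, or a methyl group added to the furan, would give a step beyond the scatter at this position.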